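The source may report more compounds than this note shows. Statements on the series, on what has been measured and on what is new or still open speak of the compounds shown alone.

Compound 2, `Oc1cccc(-c2cc(-c3ccccc3)nc(-c3ccccc3)c2)c1`, gives 0% in an assay on isolated protein for inhibition of DNA topoisomerase 1 (Homo sapiens), with a stated time of 30 min, tested at 20 uM; on this read-out higher numbers stand for a stronger effect at the one concentration tested and lower numbers for a weaker effect. Compound 3, `Oc1cccc(-c2cc(-c3ccccc3)nc(-c3cccs3)c2)c1`, gives 2% in this assay. Compound 1, `Oc1ccc(-c2cc(-c3ccccc3)cc(-c3ccc(O)cc3)n2)cc1`, has "not determined" (no result reported) in this assay.

Within the data shown here, compound 3 stands alongside compound 2, the only other compound with a number, and the step of a number 2 percentage points higher from compound 2 to compound 3 (within the scatter) shows the two lie within the scatter of one another. Compound 4, `Oc1cccc(-c2cc(-c3ccccc3)nc(-c3ccsc3)c2)c1`, differs from compound 3 in one place: thiophen-3-yl in place of thiophen-2-yl on an aromatic carbon. Among the measured compounds shown here, no measured step swaps one thiophene attachment for another; the one measured step, a number 2 percentage points higher from compound 2 to compound 3 (within the scatter), touched this same position and stayed within the scatter. For compound 4 a step of no change at the digits printed from compound 3 to compound 4 (within the scatter) is therefore expected, which is no change beyond the scatter. Compound 4 is expected to give 2% in this assay, within 0% to 10%.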

Compound 4, a percentage reported as inhibition, at one concentration (the size of the read-out at that concentration, not a potency): 3.2%
Estimate against measurement, compound 4: 1.2 percentage points below, and the stated range covers the measured number.
By their numbers in this assay, from the lowest: compounds 2, 3 and 4 (each within the scatter of the next).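

Changing how the thiophene is attached gives a number 1.2 percentage points higher from compound 3 to compound 4 (within the scatter), so thiophen-2-yl and thiophen-3-yl cannot be told apart at this position next to the ring nitrogen. Compared with phenyl, thiophen-3-yl gives a number 3.2 percentage points higher from compound 2 to compound 4 (within the scatter), so none of these three aromatic rings separates from the others in this assay. No supporting data bear on this result.

Going by these compounds, it remains open whether an amine, a carboxylic acid or a longer chain at this position would give a number beyond the scatter. Changes elsewhere on the shared core also remain untested by these comparisons.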